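Swapping methoxy for nitro on a cytotoxicity scaffold

A few compounds are considered here, and "the series" means these few. Any claim that something is new, unique, unknown or untested is made for them only; others in the source may bear on it.

Measured so far:
- Compound 1, `O=[N+]([O-])c1ccc(-c2cn3nc(Cc4ccc(Cl)cc4)sc3n2)cc1`: 214000 nM
- Compound 2, `COc1ccc(-c2nc3sc(Cc4ccc(Cl)cc4)nn3c2Br)cc1`: 63000 nM

Of the compounds shown here, two sharing a common core have been tested in a functional assay on L1210 cells (Mus musculus) for cytotoxicity, with a stated time of 48 h; on this read-out lower numbers stand for stronger inhibition and higher numbers for weaker inhibition. Compound 2 gives the lower of the two numbers; compound 1 gives a number that is higher, and the gap between the two lies beyond the usual scatter of this kind of measurement. Compound 1 carries a nitro group and no bromine on the core, while compound 2 carries a methoxy group together with a bromine on the core, so the two differ in more than one place and no single step can be read from them.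

The next compound is compound 3, `O=[N+]([O-])c1ccc(-c2nc3sc(Cc4ccc(Cl)cc4)nn3c2Br)cc1`. It is reached from compound 2 by one change: nitro in place of methoxy on an aromatic carbon. For the measured compounds named here, since no direct step for this change has been measured, its size has to be guessed. Compound 1, which also carries a nitro group, gives 214000 nM, a weaker result than compound 2. On that basis compound 3 is expected to lie somewhere between the two numbers already seen, with the step of a 1.9-fold higher number from compound 2 to compound 3 (0.28 log units; within the scatter) pointing toward weaker inhibition. The estimated value for compound 3 is 120000 nM, within a range from 40000 nM to 400000 nM.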

Compound 3, half-maximal inhibitory concentration: 94000 nM
For compound 3 the middle estimate is 1.3-fold (0.11 log units) above the measured one; the measured number falls inside the stated range.
By their numbers in this assay, from the lowest: compounds 2 and 3 (each within the scatter of the next); then compound 1.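

Nitro in place of methoxy on an aromatic carbon, para to a large group, gives a 1.5-fold higher number from compound 2 to compound 3 (0.17 log units; within the scatter) in this assay, so with bromine on the core, this swap produces no difference that can be told from the ordinary spread of repeat measurements. For the compounds shown here, the other single change now available, bromo in place of hydrogen on an aromatic carbon, gives a 2.3-fold lower number from compound 1 to compound 3 (0.36 log units; beyond the scatter), a modest step but one that lies beyond that spread, and so it is the only one of these two changes that can be read as a real difference in this set. No measurement here offers a reason for either result.

Going by these compounds, each step rests on a single pair, so it remains open whether bromo in place of hydrogen would give a step of similar size with methoxy rather than nitro on the aromatic ring. On these data alone, it also remains open how other groups would behave in these places, such as an amine or a carboxylic acid in place of nitro and methoxy, or chloro or a longer chain such as propyl in place of bromo.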